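Cyclohexyl in place of fluoro on the shared core

The source may hold more compounds than are shown below. What is called first, only, known or untested is meant among the compounds shown, and "the series" means these compounds.

Measured so far in a functional assay on L5178Y cells (Mus musculus) for inhibition; on this read-out lower numbers stand for lower potency and higher numbers for higher potency (the scale is a negative logarithm):
- compound 1, `CC1(C)N=C(N)N=C(N)N1c1cccc(C(O)c2ccccc2)c1`: compound 1 gives 6.41
- compound 2, `CC1(C)N=C(N)N=C(N)N1c1cccc(F)c1`: compound 2 gives 7.94

Within the data shown here, compound 2 stands highest of the two numbers; its nearest neighbour is compound 1, and the only step between measured compounds, a number 1.53 log units higher from compound 1 to compound 2 (beyond the scatter), runs from the hydroxy(phenyl)methyl compound to the fluoro compound and lies beyond the scatter.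

The next compound, compound 3, is `CC1(C)N=C(N)N=C(N)N1c1cccc(C2CCCCC2)c1`. Its change from compound 2 is cyclohexyl in place of fluoro on an aromatic carbon. Among the measured compounds shown here, the one step that bears on this is a number 1.53 log units higher from compound 1 to compound 2 (beyond the scatter), in which a large group gave way to fluoro and the number rose strongly. Compound 3 goes the other way, a small fluoro replaced by a large cyclohexyl, though the entering group is not the hydroxy(phenyl)methyl of compound 1, so the size of that earlier step cannot simply be carried over. For the measured compounds named here, a fall in this assay beyond the scatter is therefore expected, of a size smaller than the one step seen.

For compound 3 the expected step is a number 0.94 log units lower from compound 2 to compound 3 (beyond the scatter). The estimated value of compound 3 is 7, with a range from 6.1 to 7.9.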

Compound 3, logarithm of the reciprocal of the active concentration, log(1/C): 7.97
The estimate for compound 3 lay 0.97 log units below the measured number; measured number above the stated range.
By their numbers in this assay, from the lowest: compound 1; then compounds 2 and 3 (each within the scatter of the next).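

In this assay, the step of a number 0.03 log units higher from compound 2 to compound 3 (within the scatter) shows that this aromatic carbon accepts cyclohexyl, with 6 heavy atoms and one six-membered non-aromatic ring, in place of fluoro, with 1 heavy atom, with no separation between the two numbers, so heavy-atom count across this pair does not track the read-out. The step of a number 1.56 log units higher from compound 1 to compound 3 (beyond the scatter) puts the large fall seen earlier with compound 1 with the hydroxy(phenyl)methyl group in particular, not with large groups at this place in general, as compound 3 carries a large group and stays level with the fluoro compound 2. Nothing measured here accounts for why fluoro and cyclohexyl sit level or why hydroxy(phenyl)methyl differs from both.

Still open, going by these compounds, is which part of hydroxy(phenyl)methyl goes with the lower number, the hydroxyl or the phenyl ring, a question that a benzyl group, a hydroxymethyl group or a 4-hydroxycyclohexyl group at this carbon would begin to separate. Also open, on these data alone, is whether the level result holds for groups carrying heteroatoms, such as an amine or a carboxylic acid, at the same place.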